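The compounds below may be only part of what the source reports. "The series", "measured", "known", "first", "only" and "open" are said of these compounds alone.

In an assay on nucleic acid for binding affinity to Salmon testes DNA (Salmonidae), tested at 10 uM (a higher number here means that the compound stabilises the target more against heat, a lower number that the compound stabilises the target less), compound 3 `CC(C)CCc1sc(NC(=O)c2cc(NC(=O)c3cc(NC(=N)c4ccc(F)cc4)cn3C)cn2C)nc1C(=O)NCCCN(C)C` gives 9 degrees C, the second highest of three numbers. Compound 2 `COc1cccc(C(=N)Nc2cc(C(=O)Nc3cc(C(=O)Nc4cc(C(=O)NCCCN(C)C)n(C)c4)n(C)c3)n(C)c2)c1` reaches 11 degrees C, and compound 1 `CC(C)CCc1sc(NC(=O)c2cc(NC(=O)c3cc(NC(=N)c4cccc(F)c4)cn3C)cn2C)nc1C(=O)NCCCN(C)C` gives 4 degrees C. Compound 4 `CC(C)CCc1sc(NC(=O)c2cc(NC(=O)c3cc(NC(=N)c4cccc(Cl)c4)cn3C)cn2C)nc1C(=O)NCCCN(C)C` awaits measurement and differs from compound 3 by 3-chlorophenyl in place of 4-fluorophenyl on a carbon with a double bond to nitrogen, with 3-chlorophenyl in place of 4-fluorophenyl on a carbon with a double bond to nitrogen. Among the measured compounds shown here, one measured step bears on this: a number 5.0 degrees C higher from compound 1 to compound 3 (beyond the scatter), a large change with 4-fluorophenyl in place of 3-fluorophenyl. For the measured compounds named here, no compound with 3-chlorophenyl has yet been measured, so the reversed direction is only a guide. A drop of similar size is expected in this assay, giving an expected a number 4.0 degrees C lower from compound 3 to compound 4 (beyond the scatter). Compound 4 is estimated at 5 degrees C, within an expected range from 3 degrees C to 8 degrees C.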

Compound 4, shift of the target's melting temperature: 5 degrees C
Beside the measured number, compound 4's estimate shows no gap at the digits printed; measured number inside the range.
By their numbers in this assay, from the lowest: compounds 1 and 4 (each within the scatter of the next); then compound 3; then compound 2.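

In this assay, chloro in place of fluoro on an aromatic carbon gives a number 1.0 degrees C higher from compound 1 to compound 4 (within the scatter), so the two halogens cannot be told apart on this phenyl. The step of a number 4.0 degrees C lower from compound 3 to compound 4 (beyond the scatter) shows that a second compound, now with 3-chlorophenyl, stands lower than the 4-fluorophenyl compound, as 3-fluorophenyl did. Nothing measured here accounts for this difference. On these data alone, whether 4-chlorophenyl would match compound 3 remains open, as does what an amine or a nitrile on this phenyl would give.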